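Cyclopropyl to isopropyl: working notes on the series

The compounds below may be only part of what the source reports. "The series", "measured", "known", "first", "only" and "open" are said of these compounds alone.

Measured in a physicochemical assay for lipophilicity; on this read-out higher numbers stand for higher lipophilicity and lower numbers for lower lipophilicity:
- compound 1 `CC(C)n1cnc2c(-c3ccc(F)c(Oc4ccc(C#N)cn4)c3)cnnc21` gives 2.7
- compound 2 `Cc1cc(-c2cc(-c3cnnc4c3ncn4C3CC3)ccc2F)ccn1` gives 2.9

In this assay compound 2 stands at 2.9 and so lies within the scatter of compound 1 at 2.7. Compound 3 `Cc1cc(-c2cc(-c3cnnc4c3ncn4C(C)C)ccc2F)ccn1` has isopropyl in place of cyclopropyl on an aromatic nitrogen and is otherwise the same as compound 2. For the measured compounds named here, no measured pair shows this change alone, so the expectation is tentative. A small rise is expected, an estimated step of a number 0.20 log units higher from compound 2 to compound 3 (within the scatter) that would stay within the scatter. Compound 3 is estimated at 3.1, with an expected range of 2.8 to 3.4.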

Compound 3, distribution coefficient: 3.1
Compound 3: middle estimate and measured number agree at the digits printed, within the range that was stated.
By their numbers in this assay, from the lowest: compounds 1, 2 and 3 (each within the scatter of the next, the first and the last beyond it).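

In this assay isopropyl in place of cyclopropyl on the aromatic nitrogen gives a number 0.20 log units higher from compound 2 to compound 3 (within the scatter) as the first pair showing this change alone. For the compounds shown here, with isopropyl held on that nitrogen, 2-methylpyridin-4-yl in place of (5-cyanopyridin-2-yl)oxy on an aromatic carbon gives a number 0.40 log units higher from compound 1 to compound 3 (beyond the scatter) as the only single-place step so far beyond the scatter. No supporting evidence bears on the cause of either step.

From the compounds shown here alone, whether a longer chain or an amine-bearing chain on the aromatic nitrogen would stay within the scatter of compound 2 remains open. Also open, going by these compounds, is whether the step on the aromatic carbon would hold with cyclopropyl on the aromatic nitrogen.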